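This account rests on a few compounds, and the source may have more. Where it says the series, first, only, none or still open, it means among the compounds named here.

Compound 3 `COc1cc2c(Oc3ccc(NC(=O)c4cn(-c5ccccc5F)nn4)cc3F)ccnc2cc1OCCCN1CCN(C)CC1` gives 230 nM in a functional assay on NCI-H460 cells (Homo sapiens) for cytotoxicity, read by MTT assay, with a stated time of 72 h; on this read-out lower numbers stand for stronger inhibition and higher numbers for weaker inhibition. Among the three numbers measured it holds the second highest place: compound 2 `COc1cc2c(Oc3ccc(NC(=O)c4cn(-c5ccccc5)nn4)cc3F)ccnc2cc1OCCCN1CCN(C)CC1` gives 200 nM, while compound 1 `COc1cc2c(Oc3ccc(NC(=O)c4cn(-c5c(C)cccc5C)nn4)cc3F)ccnc2cc1OCCCN1CCCCC1` gives 3520 nM, far from compound 3. Among the compounds with values here, the one measured single-point step, a 1.2-fold higher number from compound 2 to compound 3 (0.06 log units; within the scatter), is small. Compound 4 `COc1cc2c(Oc3ccc(NC(=O)c4cn(-c5c(C)cccc5C)nn4)cc3F)ccnc2cc1OCCCN1CCN(C)CC1` differs from compound 3 by 2,6-dimethylphenyl in place of 2-fluorophenyl on an aromatic nitrogen. Within the data shown here, no measured step covers this change directly, but compound 1 carries the same 2,6-dimethylphenyl on a different tail and sits well above compound 3. A weakening step is therefore expected, namely an 8.7-fold higher number from compound 3 to compound 4 (0.94 log units; beyond the scatter). Compound 4 is estimated at 2000 nM, with a range from 600 nM to 6000 nM, because compound 1 gives 3520 nM.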

Compound 4, half-maximal inhibitory concentration: 4540 nM
Compound 4: middle estimate off by 2.3-fold (0.36 log units), on the low side, within the range that was stated.
By their numbers in this assay, from the lowest: compounds 2 and 3 (each within the scatter of the next); then compounds 1 and 4 (each within the scatter of the next).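

In this assay the 2,6-dimethylphenyl group on the aromatic nitrogen brings a large change, with a 20-fold higher number from compound 3 to compound 4 (1.30 log units; beyond the scatter) and a 23-fold higher number from compound 2 to compound 4 (1.36 log units; beyond the scatter) against a step within the scatter for the fluoro group of compound 3. The tail change shows much less, with a 1.3-fold higher number from compound 1 to compound 4 (0.11 log units; within the scatter) for 4-methylpiperazin-1-yl in place of piperidin-1-yl, so both tails carry a high number with this aryl group. No measurement shown offers a reason for the size of the aryl step.

The compounds shown leave open whether a single methyl on the phenyl ring already gives such a step. They also leave open how a chlorine or a methoxy group there would read, and how phenyl reads with the piperidin-1-yl tail.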